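Swapping a chloro for a methoxy on the sulfonamide phenyl

The source may report more compounds than this note shows. Statements on the series, on what has been measured and on what is new or still open speak of the compounds shown alone.

Measured compounds:
- compound 1, `CN(C(=O)c1ccc(Cl)cc1)c1ccc2[nH]c(-c3n[nH]c4ccccc34)cc2n1`: 630 nM
- compound 2, `CN(c1ccc2[nH]c(-c3n[nH]c4ccccc34)cc2n1)S(=O)(=O)c1ccccc1`: 2400 nM
- compound 3, `CN(c1ccc2[nH]c(-c3n[nH]c4ccccc34)cc2n1)S(=O)(=O)c1ccc(Cl)cc1`: 8350 nM

All three were tested in a functional assay on KB cells (Homo sapiens) for antiproliferative activity, read by MTT assay, with a stated time of 72 h; a higher number here means a weaker inhibitor, a lower number a stronger inhibitor. Compound 3 stands at the weak end: its number is the highest of the three, beyond the scatter from both compound 2 and compound 1. Compound 4, `COc1ccc(S(=O)(=O)N(C)c2ccc3[nH]c(-c4n[nH]c5ccccc45)cc3n2)cc1`, differs from compound 3 in one place: methoxy in place of chloro on an aromatic carbon.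

Among the measured compounds shown here, no measured pair compares a methoxy with a chloro directly. The step that comes closest is a 3.5-fold higher number from compound 2 to compound 3 (0.54 log units; beyond the scatter), which shows that putting a chloro on that carbon weakened the compound. Removing the chloro again and placing a methoxy there could therefore recover some of that loss, but the methoxy may equally carry a penalty of its own, so only a modest move is expected, towards a lower number. The expected step is a 1.9-fold lower number from compound 3 to compound 4 (0.27 log units; within the scatter). Compound 4 is thus estimated at 4500 nM, within a range of 1500 nM to 13000 nM.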

Compound 4, half-maximal inhibitory concentration: 22100 nM
Beside the measured number, compound 4's estimate is 4.9-fold (0.69 log units) below it, and the stated range ends below it.
By their numbers in this assay, from the lowest: compound 1; then compound 2; then compound 3; then compound 4.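

In this assay, the methoxy does not win back what the chloro lost: the change gives a 2.6-fold higher number from compound 3 to compound 4 (0.42 log units; beyond the scatter), and measured against plain hydrogen on the same carbon, the methoxy gives a 9.2-fold higher number from compound 2 to compound 4 (0.96 log units; beyond the scatter). Among the three sulfonamide compounds, then, both groups placed on this carbon raise the number over hydrogen, so the earlier loss with chloro was not peculiar to chloro, and methoxy costs more than chloro here. Nothing shown gives a measured reason for this order.

The compounds shown leave open whether an amine or a carboxylic acid on this carbon would also raise the number. They also leave open whether 4-methoxyphenyl in place of the 4-chlorophenyl on the carbonyl of compound 1 would shift the number the same way.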